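The compounds below may be only part of what the source reports. "The series", "measured", "known", "first", "only" and "open" are said of these compounds alone.

Measured compounds:
compound 1 `COc1cc(C)cc(-c2c(-c3ccnc(-c4ccc(C(C)=O)cc4)c3)cnn2CC#N)c1`, 63%
compound 2 `COc1cc(C)cc(-c2nn(CC#N)cc2-c2ccnc(-c3ccc(N(C)C)cc3)c2)c1`, -25%

In a functional assay on MDA-MB-435 cells (Homo sapiens) for cytotoxicity, read by sulforhodamine B assay, with a stated time of 48 h, tested at 100 nM (on this read-out higher numbers stand for a weaker effect at the one concentration tested and lower numbers for a stronger effect), compound 1 gives 63%, the highest of the two numbers, while compound 2 gives -25%, a gap beyond the scatter. The unmeasured compound 3 `COc1cc(C)cc(-c2c(-c3ccnc(-c4ccc(N(C)C)cc4)c3)cnn2CC#N)c1` comes from compound 1 by one change: dimethylamino in place of acetyl on an aromatic carbon. Among the compounds with values here, no step between measured compounds shows what this change does. Still, the expected step is a fall to a stronger effect, of size a number 58 percentage points lower from compound 1 to compound 3 (beyond the scatter), with wide uncertainty. Compound 3 is estimated at 5%, within -40% to 55%.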

Compound 3, a percentage reported as activity, at one concentration (the size of the read-out at that concentration, not a potency): -43%
Compound 3: the middle estimate sits 48 percentage points above what was measured; the measured number lies below the stated range.
By their numbers in this assay, from the lowest: compound 3; then compound 2; then compound 1.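

In this assay, the swap of 4-acetylphenyl for 4-(dimethylamino)phenyl, on an aromatic carbon para to a large group, gives a large step, a number 106 percentage points lower from compound 1 to compound 3 (beyond the scatter), so the read-out is highly sensitive to the group at this position. Acetyl and dimethylamino have the same printed heavy-atom and hydrogen-bond acceptor counts, so those counts do not separate them. Nothing available here accounts for the step. As far as these compounds go, it remains open whether a primary amine or a methoxy group on this carbon would behave like dimethylamino or like acetyl.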